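The source may hold more compounds than are shown below. What is called first, only, known or untested is meant among the compounds shown, and "the series" means these compounds.

Measured compounds:
compound 1 `CCOC(=O)c1cc(CBr)nn1[C@@H]1O[C@H](COC(C)=O)[C@@H](OC(C)=O)[C@H](OC(C)=O)[C@H]1OC(C)=O`: 5 ug/mL
compound 2 `CCOC(=O)c1cc(CBr)nn1[C@H]1O[C@H](COC(C)=O)[C@@H](OC(C)=O)[C@H](OC(C)=O)[C@H]1OC(C)=O`: 5 ug/mL
compound 3 `CCOC(=O)c1cc(CBr)nn1[C@@H]1O[C@H](COC(C)=O)[C@@H](OC(C)=O)[C@H]1OC(C)=O`: 2.5 ug/mL

In a functional assay on HeLa cells (Homo sapiens), read by colorimetric assay, with a stated time of 72 h (on this read-out lower numbers stand for an effect already at smaller amounts and higher numbers for an effect only at larger amounts of compound), compound 1 gives 5 ug/mL, level with compound 2, and its gap to compound 3 at 2.5 ug/mL lies within the scatter.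

The next compound to be measured is compound 4 `CC(=O)OC[C@H]1O[C@@H](n2nc(CBr)cc2C(N)=O)[C@H](OC(C)=O)[C@@H](OC(C)=O)[C@@H]1OC(C)=O`. Its change from compound 1 is amino in place of ethoxy on a carbonyl carbon, or ethoxycarbonyl to carbamoyl.

Among the compounds with values here, the one measured step, no change at the digits printed from compound 1 to compound 2 (within the scatter), rests on (the fact that compounds 1 and 2 differ only in the configuration as drawn). It leaves the ethoxycarbonyl untouched, so it gives no size for this change. Within the data shown here, no measured step involves this group, so the expectation is weakly founded and no firm direction can be given.

The expected step of a 1.2-fold higher number from compound 1 to compound 4 (0.08 log units; within the scatter) is therefore small, with a wide margin on either side. For compound 4 the estimate is 6 ug/mL, with an expected range of 2 ug/mL to 20 ug/mL.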

Compound 4, concentration for half-maximal effect: 4 ug/mL
The estimate for compound 4 lay 1.5-fold (0.18 log units) above the measured number, within the range that was stated.
By their numbers in this assay, from the lowest: compounds 3, 4, 1 and 2 (each within the scatter of the next).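

In this assay, within the data shown here, amino in place of ethoxy on a carbonyl carbon gives a 1.3-fold lower number from compound 1 to compound 4 (0.10 log units; within the scatter), the first measured step at this place, as compounds 1, 2 and 3 all carry ethoxycarbonyl. The carbonyl carbon therefore carries either ethoxy or amino without a step beyond the scatter, even though the swap replaces a group of three heavy atoms with a single nitrogen and adds a hydrogen-bond donor. Nothing at hand accounts for the size of this step.

Open, going by these compounds, is whether a carboxylic acid or a methylamino group on the same carbonyl carbon would also stay within the scatter of compound 1. Also open, on these data alone, is whether ethoxycarbonyl to carbamoyl reads the same on the core of compound 2 or compound 3.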